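Lengthening the nitrile chain one more carbon

The source may report more compounds than this note shows. Statements on the series, on what has been measured and on what is new or still open speak of the compounds shown alone.

Of the compounds shown here, two with the same core have been measured. Compound 1 `C=CCc1cc(C(C)=O)c(O)cc1OCCCC#N` gives in an assay on isolated protein for binding affinity to leukotriene B4 receptor 1 (Homo sapiens), tested at 1 uM (on this read-out lower numbers stand for less inhibition and higher numbers for more inhibition at the one concentration tested (going by the name of the read-out)), a value of 6%, while compound 2 `C=CCc1cc(C(C)=O)c(O)cc1OCCCCC#N` gives 57%. Compound 2 thus stands highest of the two numbers, and the step of a number 51 percentage points higher from compound 1 to compound 2 (beyond the scatter) is well beyond the scatter. Compound 3 `C=CCc1cc(C(C)=O)c(O)cc1OCCCCCC#N` is the next member of the same series, where the change is cyanomethyl in place of cyano on a saturated chain carbon, four bonds along the chain from an oxygen on an aromatic ring, on a saturated chain carbon four bonds along the chain from the oxygen on the aromatic ring. For the measured compounds named here, only the single step from compound 1 to compound 2 bears on this, and it was large and upward. A further rise of similar size cannot be assumed from one step alone, so the expectation is a modest increase, a number 8 percentage points higher from compound 2 to compound 3 (within the scatter). For compound 3 the estimated value is 65%, within a range from 35% to 90%.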

Compound 3, a percentage reported as inhibition, at one concentration (the size of the read-out at that concentration, not a potency): 41%
The estimate for compound 3 lay 24 percentage points above the measured number; measured number inside the range.
By their numbers in this assay, from the lowest: compound 1; then compound 3; then compound 2.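

Adding a further carbon to the chain does not extend the earlier rise in this assay but reverses it: cyanomethyl in place of cyano, on a saturated chain carbon, four bonds along the chain from an oxygen on an aromatic ring, gives (a number 16 percentage points lower from compound 2 to compound 3 (beyond the scatter)). Even so, the 4-cyanobutyl chain keeps much of the gain over the shortest chain (a number 35 percentage points higher from compound 1 to compound 3 (beyond the scatter)), so among these three compounds the number peaks at compound 2 instead of climbing steadily. Nothing measured here explains this turn.

A longer chain would show whether the number keeps falling or levels off. A carboxylic acid or an amine at the chain end would show whether the nitrile itself is needed or whether chain length alone sets the result.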